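The compounds below may be only part of what the source reports. "The series", "measured", "known", "first", "only" and "open" are said of these compounds alone.

Compound 1 `O=C(Nc1ccccc1)c1csc(Cc2c(Cl)cccc2Cl)n1` gives > 4000 nM in an assay on CHO cells, read by calcium flux (a lower number here means a stronger inhibitor, a higher number a weaker inhibitor), which is a limit of the assay rather than a number. Among the measured compounds shown here, compound 2 `N#Cc1ccc(NC(=O)c2csc(Cc3c(Cl)cccc3Cl)n2)cc1` gives 450 nM in this assay, and the step of an at least 8.8-fold lower number from compound 1 to compound 2 (0.94 log units; beyond the scatter) is the only measured step in the set. Compound 3 `O=C(Nc1ccc(C(F)(F)F)cc1)c1csc(-c2c(Cl)cccc2Cl)n1` gives > 4000 nM in this assay, again a limit, so that compound 3 stands only at the limit of > 4000 nM in this assay, at which 2 of the 3 values shown sit. Compound 4 `Cc1cccc(C)c1Nc1nc(C(=O)Nc2ccc(C(F)(F)F)cc2)cs1` differs from compound 3 by (2,6-dimethylphenyl)amino in place of 2,6-dichlorophenyl on an aromatic carbon. No measured step touches this change, so the numbers shown set neither direction nor size for it, and the estimate can start only from where compound 3 sits. Compound 4 is therefore expected near 5000 nM, within 1500 nM to 20000 nM. The expected step is a step that the limit leaves unreadable from compound 3 to compound 4.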

Compound 4, half-maximal inhibitory concentration: 90 nM
For compound 4 the middle estimate is 56-fold (1.74 log units) above the measured one; the measured number lies below the stated range.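

Changing 2,6-dichlorophenyl to (2,6-dimethylphenyl)amino on this aromatic carbon gives an at least 44-fold lower number from compound 3 to compound 4 (1.64 log units; beyond the scatter) in this assay. Among the compounds shown here, the only earlier step changed another place, the anilide ring, so this is the first sign that this position can also move the result. The reading of compound 3 is a limit of the assay, so the step has only a lower bound: the limit of > 4000 nM in this assay, at which 2 of the 4 values shown sit.

The swap changes the link and the ring substituents together, so the compounds shown do not tell which of these matters. A (2,6-dichlorophenyl)amino group at this position would separate the two.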